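A few compounds are considered here, and "the series" means these few. Any claim that something is new, unique, unknown or untested is made for them only; others in the source may bear on it.

Compound 1 `COc1ccc(Nc2nc(Cl)cn([C@H](C)C3CC3)c2=O)c(C)n1` gives 89%
Compound 2 `COc1cc(C)c(Nc2nc(Cl)cn([C@H](C)C3CC3)c2=O)c(C)n1` gives 79%
Compound 3 `Cc1cc(Nc2nc(Cl)cn([C@H](C)C3CC3)c2=O)c(C)nc1N1CCCC1` gives 57%

In an ADME assay on microsomes from liver (Rattus norvegicus) for metabolic stability, with a stated time of 10 min (on this read-out lower numbers stand for a less stable compound and higher numbers for a more stable compound), compound 2 stands at 79%, within the scatter of compound 1 and clearly above compound 3 . Compound 4 `Cc1cc(OC(F)F)nc(C)c1Nc1nc(Cl)cn([C@H](C)C2CC2)c1=O` differs from compound 2 by one change: difluoromethyl in place of methyl on an oxygen on an aromatic ring. In words, this is difluoromethyl in place of methyl on an oxygen on an aromatic ring, or methoxy to difluoromethoxy. Among the compounds with values here, no measured step tests this change. The only one, a number 10 percentage points lower from compound 1 to compound 2 (within the scatter), is methyl in place of hydrogen on an aromatic carbon, so it bears only loosely. No step beyond the scatter is therefore expected, and the estimated step is a number 3 percentage points higher from compound 2 to compound 4 (within the scatter). Compound 4 is expected at 82%, with an estimated range of 66% to 95%.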

Compound 4, percent of the compound remaining in the Rattus norvegicus assay: 89%
For compound 4 the middle estimate is 7 percentage points below the measured one; the range from low to high includes it.
By their numbers in the Rattus norvegicus assay, from the lowest: compound 3; then compounds 2, 1 and 4 (each within the scatter of the next).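

In the Rattus norvegicus assay the change from methoxy to difluoromethoxy gives a number 10 percentage points higher from compound 2 to compound 4 (within the scatter), so this read-out does not separate the two compounds. In a physicochemical assay for acid dissociation, read by spectrophotometry, at pH 2, the same change gives a number at least 1.80 log units lower from compound 2 to compound 4 (beyond the scatter), so here the two compounds do part. In the physicochemical assay compound 2 gives 3.8. In the physicochemical assay compound 4 gives < 2, which is a limit of the assay and not a number.

From the compounds shown here alone, this change is seen in one pair only, so whether it reads alike on the core of compound 1 stays open. Also open, going by these compounds, is how a trifluoromethyl or a longer chain on this oxygen would read in the Rattus norvegicus assay.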